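Compound 2 to compound 4: methoxy replaced

A few compounds are considered here, and "the series" means these few. Any claim that something is new, unique, unknown or untested is made for them only; others in the source may bear on it.

In a physicochemical assay for solubility, with a stated time of 24 h, at pH 4.5 (on this read-out higher numbers stand for higher solubility and lower numbers for lower solubility), compound 1 (`COC(=O)c1ccc2ccc(C(=O)N(C)C)c-2cc1`) gives 50 ug/mL. Compound 2 (`COC(=O)c1ccc2ccc(C(=O)c3ccccc3)c-2cc1`) gives < 1 ug/mL, which is a limit and not a number. Compound 3 (`COC(=O)c1ccc2ccc(C(=O)Nc3ccccc3)c-2cc1`) gives < 1 ug/mL, also a limit. Compound 2 thus stands at the limit of < 1 ug/mL in this assay, at which 2 of the 3 values shown sit, and its actual value is not known.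

Compound 4 (`O=C(NCCO)c1ccc2ccc(C(=O)c3ccccc3)c-2cc1`) carries (2-hydroxyethyl)amino in place of methoxy on a carbonyl carbon. Within the data shown here, no measured step makes this change, as compounds 1, 2 and 3 all keep the methoxy group. The nearest evidence comes from changes of a different carbonyl substituent: an at least 50-fold lower number from compound 1 to compound 2 (1.69 log units; beyond the scatter) and an at least 50-fold lower number from compound 1 to compound 3 (1.69 log units; beyond the scatter). Both are large and show that this assay can move widely within the series, but they do not fix a direction for the new change. A moderate upward step is tentatively expected, with the estimate being an at least 3.0-fold higher number from compound 2 to compound 4 (0.47 log units; beyond the scatter). For compound 4 the expected value is 3 ug/mL, within an estimated range of 0.7 ug/mL to 15 ug/mL.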

Compound 4, solubility: 6 ug/mL
Beside the measured number, compound 4's estimate is 2.0-fold (0.30 log units) below it, and the stated range covers the measured number.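

Exchanging the methoxy group for (2-hydroxyethyl)amino gives, in this assay, an at least 6.0-fold higher number from compound 2 to compound 4 (0.77 log units; beyond the scatter). This is the first rise shown in the series, and it comes from the methoxy place with the phenyl on the other carbonyl carbon kept, whereas the earlier readable steps, both at that other carbonyl carbon, go down and the step between the two limits cannot be read. Compound 2 stands at a limit and not a number, so the new step has only a lower bound: the limit of < 1 ug/mL in this assay, at which 2 of the 4 values shown sit.

A methylamino group, a longer chain ending in an amine, or a carboxylic acid at this place would help show which part of the (2-hydroxyethyl)amino group goes with the rise. From the compounds shown here alone, whether the same change carries over with dimethylamino or anilino on the other carbonyl carbon remains open.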